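The source may report more compounds than this note shows. Statements on the series, on what has been measured and on what is new or still open speak of the compounds shown alone.

Of the compounds shown here, three built on one shared core have been tested in a functional assay on DU-145 cells (Homo sapiens) for inhibition, read by trypan blue exclusion, with a stated time of 96 h; on this read-out lower numbers stand for stronger inhibition of growth and higher numbers for weaker inhibition of growth. Compound 1 `COc1ccc(/C=C(/Sc2ccc(Br)cc2)C(=O)c2ccc(Br)cc2)cc1` gives 25000 nM, compound 3 `COc1ccc(/C=C(/Sc2ccc(Br)cc2)C(=O)c2ccc(Br)cc2)c(F)c1` gives 20000 nM, and compound 2 `O=C(/C(=C\c1ccc(Br)c(O)c1)Sc1ccc(Br)cc1)c1ccc(Br)cc1` gives 1000 nM, the lowest number of the three and the strongest growth inhibition in this small set. Fluoro in place of hydrogen on an aromatic carbon gives a 1.3-fold lower number from compound 1 to compound 3 (0.10 log units; within the scatter). Putting 4-bromo-3-hydroxyphenyl in place of 4-methoxyphenyl gives a 25-fold lower number from compound 1 to compound 2 (1.40 log units; beyond the scatter), and 2-fluoro-4-methoxyphenyl in place of 4-bromo-3-hydroxyphenyl gives a 20-fold higher number from compound 2 to compound 3 (1.30 log units; beyond the scatter).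

Compound 4 `O=C(/C(=C\c1ccc(Br)c([N+](=O)[O-])c1)Sc1ccc(Br)cc1)c1ccc(Br)cc1` keeps everything in compound 2 except one group, with nitro in place of hydroxy on an aromatic carbon, ortho to a bromo group (nitro in place of hydroxy on an aromatic carbon). Going by the values given here, neither large step isolates the hydroxy, as each swaps the whole substituted phenyl group, and no nitro compound has been measured. Even so, the one compound carrying the hydroxy is the one that stands apart, by a 25-fold lower number from compound 1 to compound 2 (1.40 log units; beyond the scatter). Compound 4 loses that hydroxy but keeps the bromo group, so a partial loss seems likely. The expected change is a 3.5-fold higher number from compound 2 to compound 4 (0.54 log units; beyond the scatter), a higher number but a smaller step than the two large ones. For compound 4 the estimated value is 3500 nM, with an expected range from 800 nM to 15000 nM.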

Compound 4, concentration for 50% growth inhibition: 1000 nM
Estimate against measurement, compound 4: 3.5-fold (0.54 log units) above; measured number inside the range.
By their numbers in this assay, from the lowest: compounds 2 and 4 (each within the scatter of the next); then compounds 3 and 1 (each within the scatter of the next).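

Swapping hydroxy for nitro on the aromatic carbon ortho to a bromo group gives no change at the digits printed from compound 2 to compound 4 (within the scatter) in this assay, so this position accepts two quite different groups without a change beyond the scatter. The entering nitro has more heavy atoms than the hydroxy and no hydrogen-bond donor, so a hydroxy, and a hydrogen-bond donor at this place, are not required for a number at the level of compound 2, and the large gain seen when the whole phenyl group was swapped cannot be credited to the hydroxy alone. No measurement shown here explains why these two groups give matching numbers.

What the compounds leave open is whether any group is needed at this position at all, since plain hydrogen does not appear there alongside the bromo group, and whether an amine, a carboxylic acid or a longer chain such as ethoxy would also hold the number. Going by these compounds alone, the role of the bromo group is open too, as both compound 2 and compound 4 carry it and no compound shows either group on this ring with that bromo group replaced by hydrogen.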